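The source may hold more compounds than are shown below. What is called first, only, known or untested is meant among the compounds shown, and "the series" means these compounds.

Measured so far:
compound 1, `Nc1ncc(-c2ccc(C(=O)N3CC(O)C3)cc2)nc1-c1ccc(C(F)(F)F)cc1`, 110000 nM;
compound 2, `Nc1ncc(-c2ccc(C(=O)N3CC[C@@H](O)C3)cc2)nc1-c1ccc(C(F)(F)F)cc1`, 103000 nM.

Both numbers come from a physicochemical assay for solubility, read by HPLC, using the shake flask method, with a stated time of 2 h, at pH 2; a lower number here means a less soluble compound, a higher number a more soluble compound. Compound 2 gives the lowest of the two numbers, but its nearest neighbour is compound 1 and the gap between them is a 1.1-fold lower number from compound 1 to compound 2 (0.03 log units; within the scatter), so the two compounds cannot be set in order.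

Compound 3 is `COC(=O)c1ccc(-c2cnc(N)c(-c3ccc(C(F)(F)F)cc3)n2)cc1`. Its difference from compound 2 is methoxy in place of 3-hydroxypyrrolidin-1-yl on a carbonyl carbon. For the measured compounds named here, the only measured step, from compound 1 to compound 2, exchanges one hydroxylated ring for another and keeps the 3-hydroxy group in both; it says nothing about removing that group in favour of methoxy. Going by the values given here, no measured pair therefore bears directly on this change, and the expectation rests on the change itself rather than on an observed step.

Since compound 1 and compound 2 sit close together in this assay, the starting point is well defined. Compound 3 is expected to give a lower number, with the step from compound 2 to compound 3 estimated at a 4.1-fold lower number from compound 2 to compound 3 (0.61 log units; beyond the scatter). Among the compounds with values here, the estimate for compound 3 is 25000 nM, in a range from 5000 nM to 100000 nM; the range is wide, as no measured step covers this kind of change.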

Compound 3, solubility: < 5000 nM
Compound 3 was reported as a limit (the forecaster's own chance of this, stated with the estimate: 5%); middle value at least 5.0-fold (0.69 log units) away from the limit.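

The two hydroxylated rings could not be set apart, but replacing the ring on the carbonyl carbon with methoxy gives a clear separation in this assay: the result is an at least 20-fold lower number from compound 2 to compound 3 (1.31 log units; beyond the scatter), and against the smaller ring it is an at least 22-fold lower number from compound 1 to compound 3 (1.34 log units; beyond the scatter). What sits on this carbonyl carbon therefore matters for the read-out, even though 3-hydroxyazetidin-1-yl and 3-hydroxypyrrolidin-1-yl read alike there. Compound 3 is reported only as a limit, so both steps set a minimum and not a full size, because its value lies at that limit: the limit of < 5000 nM in this assay, at which 1 of the 3 values shown sits.

The change removes the ring, its hydroxy group and the amide nitrogen in a single step, so the compounds shown do not tell which of these parts accounts for the difference. From the compounds shown here alone, it remains open whether a pyrrolidin-1-yl group without the hydroxy group, a dimethylamino group or a carboxylic acid on the same carbonyl carbon would read with compound 1 and compound 2 or with compound 3.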